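This account rests on a few compounds, and the source may have more. Where it says the series, first, only, none or still open, it means among the compounds named here.

Measured in an ADME assay on HEK293 cells (Homo sapiens) for cytotoxicity, read by MTT assay, with a stated time of 48 h; a lower number here means a stronger inhibitor, a higher number a weaker inhibitor:
Compound 1 `C=C1CCC[C@]2(C)CCC(c3cn(-c4ccc(OC)cc4)nn3)=CC[C@@]12C`: 410000 nM
Compound 2 `C=C1CCC[C@]2(C)CCC(c3cn(-c4cccc([N+](=O)[O-])c4)nn3)=CC[C@@]12C`: 699000 nM
Compound 3 `C=C1CCC[C@]2(C)CCC(c3cn(-c4ccc(I)cc4)nn3)=CC[C@@]12C`: 215000 nM

In this assay, compound 3 gives 215000 nM. Among the compounds with values here, only one comparison separates it clearly from the others, a 3.3-fold lower number from compound 2 to compound 3 (0.51 log units; beyond the scatter). By contrast, a 1.9-fold lower number from compound 1 to compound 3 (0.28 log units; within the scatter) leaves no real difference from the 4-methoxyphenyl compound.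

Compound 4 `C=C1CCC[C@]2(C)CCC(c3cn(-c4ccccc4C(C)=O)nn3)=CC[C@@]12C` keeps the shared core and alters only the group on the aromatic nitrogen: 2-acetylphenyl in place of 4-iodophenyl on an aromatic nitrogen. In words, this is 2-acetylphenyl in place of 4-iodophenyl on an aromatic nitrogen.

Within the data shown here, all three measured steps exchange the group at this same place, so all three bear on the change, although none of the measured compounds carries 2-acetylphenyl. Two of them stayed within the scatter, a 1.7-fold higher number from compound 1 to compound 2 (0.23 log units; within the scatter) and a 1.9-fold lower number from compound 1 to compound 3 (0.28 log units; within the scatter). The largest, a 3.3-fold lower number from compound 2 to compound 3 (0.51 log units; beyond the scatter), was modest and ended on the 4-iodophenyl group that now leaves. A small upward move is therefore expected, one that would not stand clear of the scatter. The expected step is a 1.8-fold higher number from compound 3 to compound 4 (0.25 log units; within the scatter). The estimate for compound 4 is 380000 nM, with an expected range from 170000 nM to 800000 nM.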

Compound 4, half-maximal inhibitory concentration: 524000 nM
The estimate for compound 4 lay 1.4-fold (0.14 log units) below the measured number; measured number inside the range.
By their numbers in this assay, from the lowest: compounds 3, 1, 4 and 2 (each within the scatter of the next, the first and the last beyond it).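

In this assay, the change to 2-acetylphenyl gives a second step beyond the scatter at this position, a 2.4-fold higher number from compound 3 to compound 4 (0.39 log units; beyond the scatter), although a modest one, and like the earlier step from compound 2 it involves the 4-iodophenyl group. Compound 3 thus now stands clearly apart from two of the three other groups on the aromatic nitrogen, while its difference from compound 1 remains within the scatter. The 2-acetylphenyl group, with its hydrogen-bond acceptor and larger heavy-atom count, cannot be told apart from either 3-nitrophenyl (a 1.3-fold lower number from compound 2 to compound 4 (0.13 log units; within the scatter)) or 4-methoxyphenyl (a 1.3-fold higher number from compound 1 to compound 4 (0.11 log units; within the scatter)), and nothing measured here accounts for the step away from 4-iodophenyl.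

Going by these compounds, all four compounds carry a substituted phenyl ring at this position, so how an amine, a carboxylic acid or a longer alkyl chain on that ring would read in this assay remains open. Also open, on these data alone, is whether the acetyl or iodo group would give a similar number at another place on the phenyl ring, since each appears here at only one place.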